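The source may hold more compounds than are shown below. What is called first, only, known or untested is meant among the compounds shown, and "the series" means these compounds.

The measured compounds:
Compound 1 `Cc1ccc(Sc2cnc(Nc3ccccn3)s2)cc1C(=O)NC(C)C` gives 2000 nM in an assay on isolated protein for inhibition of high affinity nerve growth factor receptor (Homo sapiens); on this read-out higher numbers stand for weaker inhibition and lower numbers for stronger inhibition.
Compound 2 `Cc1ccc(Sc2cnc(Nc3ccccn3)s2)cc1C(=O)NCC#N` gives 44 nM in this assay.
Compound 3 `Cc1ccc(Sc2cnc(Nc3ccccn3)s2)cc1C(=O)NCCC#N` gives 65 nM in this assay.

Compound 2 has the lowest number of the three: a 45-fold lower number from compound 1 to compound 2 (1.66 log units; beyond the scatter), whereas a 1.5-fold higher number from compound 2 to compound 3 (0.17 log units; within the scatter). Compound 4 `Cc1ccc(Sc2cnc(Nc3ccccn3)s2)cc1C(=O)NCCO` differs from compound 2 by hydroxymethyl in place of cyano on a saturated chain carbon bound to an amide-type nitrogen. Within the data shown here, two measured steps bear on this: a 45-fold lower number from compound 1 to compound 2 (1.66 log units; beyond the scatter) and a 31-fold lower number from compound 1 to compound 3 (1.49 log units; beyond the scatter), both large, while a 1.5-fold higher number from compound 2 to compound 3 (0.17 log units; within the scatter) shows no step beyond the scatter. Among the measured compounds shown here, no measured pair exchanges cyano for hydroxymethyl, so the entering hydrogen-bond donor is untested here; the expected step is a 2.3-fold higher number from compound 2 to compound 4 (0.36 log units; beyond the scatter), modest and uncertain. Compound 4 is therefore estimated at 100 nM, with a range from 30 nM to 400 nM.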

Compound 4, half-maximal inhibitory concentration: 760 nM
Beside the measured number, compound 4's estimate is 7.6-fold (0.88 log units) below it; measured number above the stated range.
By their numbers in this assay, from the lowest: compounds 2 and 3 (each within the scatter of the next); then compound 4; then compound 1.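

In this assay, among these compounds, the earlier compounds showed that the nitrile chains beat isopropyl, and this result shows that not just any small chain end does the same: ending the chain in hydroxy instead of nitrile gives a 17-fold higher number from compound 2 to compound 4 (1.24 log units; beyond the scatter) and a 12-fold higher number from compound 3 to compound 4 (1.07 log units; beyond the scatter). Only a modest gain over isopropyl remains, with a 2.6-fold lower number from compound 1 to compound 4 (0.42 log units; beyond the scatter). No available measurement explains this loss.

The compounds shown leave open how an amine or a carboxylic acid at the end of this chain would compare with the nitrile and the hydroxy.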